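From 2-nitrophenyl to 4-fluorophenyl on the shared core

The compounds below may be only part of what the source reports. "The series", "measured", "known", "first", "only" and "open" are said of these compounds alone.

In a functional assay on Jurkat cells (Homo sapiens) (a higher number here means a weaker inhibitor, a lower number a stronger inhibitor), compound 1 `CC(C)[C@H](NC(=O)COc1cccc2ccccc12)C(=O)N[C@@H](CC(=O)O)C(=O)COc1ccccc1` gives 14000 nM. Compound 2 `CC(C)[C@H](NC(=O)COc1cccc2ccccc12)C(=O)N[C@@H](CC(=O)O)C(=O)COc1ccccc1[N+](=O)[O-]` stands only at a limit, > 100000 nM. Compound 3 `CC(C)[C@H](NC(=O)COc1cccc2ccccc12)C(=O)N[C@@H](CC(=O)O)C(=O)COc1ccc(F)cc1` differs from it by 4-fluorophenyl in place of 2-nitrophenyl on an oxygen on a saturated carbon, with 4-fluorophenyl in place of 2-nitrophenyl on an oxygen on a saturated carbon. For the measured compounds named here, the one measured step bearing on this is an at least 7.1-fold higher number from compound 1 to compound 2 (0.85 log units; beyond the scatter), which came with nitro in place of hydrogen on an aromatic carbon. Going by the values given here, no measured step covers the fluorine. With the nitro gone, a change of similar size toward a lower number is expected, an at least 7.6-fold lower number from compound 2 to compound 3 (0.88 log units; beyond the scatter). For compound 3 the estimate is 13000 nM, within an expected range of 4500 nM to 40000 nM.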

Compound 3, half-maximal inhibitory concentration: > 100000 nM
Compound 3 ended at the assay's limit; the forecaster's own chance of this, stated with the estimate: 10%; at least 7.6-fold (0.88 log units) between middle value and limit.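

The 4-fluorophenoxy group brought an at least 7.1-fold higher number from compound 1 to compound 3 (0.85 log units; beyond the scatter), so the nitro group of compound 2 is not needed for a loss at this position. Of the three phenoxy groups shown, only the unsubstituted one in compound 1 gives a readable value. The step between compound 2 and compound 3 cannot be read, since each of these compounds sits at a limit and not at a number: the limit of > 100000 nM in this assay, at which 2 of the 3 values shown sit.

As far as these compounds go, how far compound 2 and compound 3 lie beyond compound 1 remains open. So does whether an amine or a methoxy group on this ring would keep the value of compound 1 or lower it.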